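Shortening the ether side chain of compound 3

A few compounds are considered here, and "the series" means these few. Any claim that something is new, unique, unknown or untested is made for them only; others in the source may bear on it.

Compound 1 `CCOc1nc(N)nc2[nH]cnc12`: > 1000000 nM
Compound 2 `CCCCCCCOc1nc(N)nc2[nH]cnc12`: > 100000 nM
Compound 3 `C=C(CC)COc1nc(N)nc2[nH]cnc12`: 16000 nM

Three compounds sharing one core differ only in the group attached through an oxygen on the aromatic ring. Among the compounds with values here, in an assay on HT-29 cells for inhibition of Methylated-DNA--protein-cysteine methyltransferase (Homo sapiens) (a higher number here means a weaker inhibitor, a lower number a stronger inhibitor), compound 3 gives 16000 nM, the only outright number among the three. For compound 1 the result > 1000000 nM is a limit of this assay, not a number. For compound 2 the result > 100000 nM is likewise a limit. Both steps toward compound 3 are therefore read as lower bounds: an at least 62-fold lower number from compound 1 to compound 3 (1.79 log units; beyond the scatter) and an at least 6.2-fold lower number from compound 2 to compound 3 (0.79 log units; beyond the scatter). Within the data shown here, compound 3 thus stands as the one compound with a measurable number; the step from compound 1 to compound 2 is not readable, a step that the two limits leave unreadable from compound 1 to compound 2.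

Compound 4 `C#CCOc1nc(N)nc2[nH]cnc12` carries a smaller group at the same place: a group of 2 heavy atoms (2 carbon; no ring) in place of a group of 4 heavy atoms (4 carbon; no ring), on a saturated chain carbon bound to an oxygen on an aromatic ring. The closest guide is the move from compound 1 to compound 3, where a smaller group gave a much weaker inhibitor, an at least 62-fold lower number from compound 1 to compound 3 (1.79 log units; beyond the scatter). Shrinking the group again is therefore expected to raise the number, and a step of about a 6.3-fold higher number from compound 3 to compound 4 (0.80 log units; beyond the scatter) is estimated. For compound 4 the expected value is 100000 nM, within a range of 20000 nM to 1000000 nM.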

Compound 4, half-maximal inhibitory concentration: 20000 nM
Estimate against measurement, compound 4: 5.0-fold (0.70 log units) above, within the range that was stated.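

At this place, on a saturated chain carbon bound to an oxygen on an aromatic ring, this assay does not separate the ethynyl group from the larger group it replaces, with a 1.3-fold higher number from compound 3 to compound 4 (0.10 log units; within the scatter). The measurable inhibition of compound 3 therefore does not depend on that group of 4 heavy atoms with its double bond, since a smaller group with a triple bond also gives a measured number, and the new compound also stands clear of the two earlier ones, with an at least 50-fold lower number from compound 1 to compound 4 (1.69 log units; beyond the scatter) and an at least 5.0-fold lower number from compound 2 to compound 4 (0.69 log units; beyond the scatter). Those last two steps are only lower bounds, as the results for compound 1 and compound 2 are limits of the assay, not numbers.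

Going by these compounds, whether the double or triple bond matters at all stays open, and a plain propyl chain at the same place would test that directly. Also open, on these data alone, is how a benzyl group or a chain ending in an amine would compare with compound 3 and compound 4, so the reach of this position is known only for small chains.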